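The source may hold more compounds than are shown below. What is called first, only, known or untested is meant among the compounds shown, and "the series" means these compounds.

Measured so far:
- compound 1, `CC(=O)OC[C@H]1O[C@H](NS(=O)(=O)c2ccc(C)cc2)C(OC(C)=O)=C[C@@H]1OC(C)=O`: 34900000 nM
- compound 2, `CCS(=O)(=O)N[C@@H]1C=C[C@H](OC(C)=O)[C@@H](COC(C)=O)O1`: 280000000 nM

In a functional assay on A549 cells (Homo sapiens) for cytotoxicity, read by MTT assay, with a stated time of 24 h (on this read-out lower numbers stand for stronger inhibition and higher numbers for weaker inhibition), compound 2 gives 280000000 nM, the highest of the two numbers recorded; the nearest is compound 1, whose number is lower by a margin beyond the usual scatter of this assay. Both values lie at very high concentrations, so neither compound is a strong inhibitor of cell growth.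

Compound 3, `CCS(=O)(=O)N[C@H]1O[C@H](COC(C)=O)[C@@H](OC(C)=O)C=C1OC(C)=O`, is not yet measured. It differs from compound 2 in one place: acetoxy in place of hydrogen on a double-bonded ring carbon. Among the measured compounds shown here, no pair of measured compounds shows this exact change, so there is no measured step to lean on. Compound 3 is expected to give a somewhat lower number than compound 2, a step of a 3.5-fold lower number from compound 2 to compound 3 (0.54 log units; beyond the scatter), because compound 2 sits at 280000000 nM with room to move downward. The estimate for compound 3 is 80000000 nM, within a range from 20000000 nM to 300000000 nM.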

Compound 3, half-maximal inhibitory concentration: 21900000 nM
For compound 3 the middle estimate is 3.7-fold (0.56 log units) above the measured one; the measured number falls inside the stated range.
By their numbers in this assay, from the lowest: compounds 3 and 1 (each within the scatter of the next); then compound 2.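

In this assay, acetoxy in place of hydrogen on the double-bonded ring carbon gives a 13-fold lower number from compound 2 to compound 3 (1.11 log units; beyond the scatter), the first sign that this position, two ring bonds from the ring oxygen, can shift the number substantially. With that acetoxy present, ethyl in place of 4-methylphenyl on the sulfonyl sulfur gives a 1.6-fold lower number from compound 1 to compound 3 (0.20 log units; within the scatter), so this change at the sulfonyl group cannot be told apart from scatter. Nothing available explains the size of the acetoxy step.

Going by these compounds, it remains open whether a hydroxy or methoxy group on the same ring carbon would give a similar step, or whether it depends on acetoxy itself. Also open, on these data alone, is whether the acetoxy step recurs with 4-methylphenyl on the sulfonyl sulfur, and how a longer chain or an amine there would read.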